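Replacing Thiophene with Thiazole: An Expectation

A few compounds are considered here, and "the series" means these few. Any claim that something is new, unique, unknown or untested is made for them only; others in the source may bear on it.

Measured so far in an assay on RBL-1 cells for inhibition of Polyunsaturated fatty acid 5-lipoxygenase (Rattus norvegicus); a lower number here means a stronger inhibitor, a higher number a weaker inhibitor:
compound 1 `COc1cccc(N2CCNC(=O)N2)c1` gives 47000 nM
compound 2 `O=C1NCCN(c2cccc(-c3ccsc3)c2)N1` gives 4900 nM

Compound 2 has the lowest number of the two; its nearest neighbour is compound 1, and the step of a 9.6-fold lower number from compound 1 to compound 2 (0.98 log units; beyond the scatter) came with thiophen-3-yl in place of methoxy on an aromatic carbon. Compound 3 `O=C1NCCN(c2cccc(-c3nccs3)c2)N1` is not yet measured. It differs from compound 2 by 1,3-thiazol-2-yl in place of thiophen-3-yl on an aromatic carbon. For the measured compounds named here, no measured step concerns this change: the one known step swaps a methoxy for a five-membered aromatic ring, whereas here one five-membered aromatic ring gives way to another of the same size. The step is therefore expected to stay within the scatter, in no clear direction, so compound 3 is expected at about 6000 nM (range 2000 nM to 20000 nM), which would mean a step of a 1.2-fold higher number from compound 2 to compound 3 (0.09 log units; within the scatter).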

Compound 3, half-maximal inhibitory concentration: 35000 nM
For compound 3 the middle estimate is 5.8-fold (0.77 log units) below the measured one; measured number above the stated range.
By their numbers in this assay, from the lowest: compound 2; then compounds 3 and 1 (each within the scatter of the next).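

In this assay, this place on the aromatic ring proves sensitive to more than ring size: exchanging one five-membered aromatic ring for another of the same heavy-atom count, with a ring nitrogen in the entering group, gives a 7.1-fold higher number from compound 2 to compound 3 (0.85 log units; beyond the scatter). The gain over methoxy therefore belongs to thiophen-3-yl and not to five-membered aromatic rings as such, since 1,3-thiazol-2-yl matches methoxy within the scatter, the step being a 1.3-fold lower number from compound 1 to compound 3 (0.13 log units; within the scatter). No measurement at hand speaks to what lies behind this loss.

The compounds shown leave open whether a phenyl or a furan-3-yl group at this place would keep the number of compound 2. They also leave open whether a thiazole joined through a different ring carbon would resemble compound 2 or compound 3.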